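A few compounds are considered here, and "the series" means these few. Any claim that something is new, unique, unknown or untested is made for them only; others in the source may bear on it.

Compound 3 `CCOc1ccc(-n2nncc2CN2C(=O)C3(C(C#N)=C(N)Oc4c(N)cc5nc6ccccc6nc5c43)c3ccccc32)cc1` carries a 4-ethoxyphenyl group on the aromatic nitrogen of its triazole ring. In a functional assay on HepG2 cells (Homo sapiens) for antiproliferative activity, read by MTT assay, with a stated time of 48 h (a lower number here means a stronger inhibitor, a higher number a weaker inhibitor), compound 3 gives only a limit, > 50000 nM, and not a number. Compound 1 `Cc1ccccc1-n1nncc1CN1C(=O)C2(C(C#N)=C(N)Oc3c(N)cc4nc5ccccc5nc4c32)c2ccccc21`, which bears a 2-methylphenyl group at the same position, likewise gives only the limit > 50000 nM in this assay. Compound 2 `N#CC1=C(N)Oc2c(N)cc3nc4ccccc4nc3c2C12C(=O)N(Cc1cnnn1-c1cccc(Br)c1)c1ccccc12`, with a 3-bromophenyl group there, also reaches only the limit > 50000 nM in this assay. Every value shown thus sits at the same limit, as the limit of > 50000 nM in this assay, at which 3 of the 3 values shown sit, records, so compound 3 stands nowhere distinguishable from the other two.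

Compound 4 `N#CC1=C(N)Oc2c(N)cc3nc4ccccc4nc3c2C12C(=O)N(Cc1cnnn1-c1ccc(Cl)cc1Cl)c1ccccc12` differs from compound 3 in one place: 2,4-dichlorophenyl in place of 4-ethoxyphenyl on an aromatic nitrogen. The measured steps that bear on this exchange of the aryl group on the aromatic nitrogen are a step that the two limits leave unreadable from compound 1 to compound 2, a step that the two limits leave unreadable from compound 1 to compound 3 and a step that the two limits leave unreadable from compound 2 to compound 3, all of them unreadable because both ends sit at the limit. None of them gives a size or a direction, and three different aryl groups at this position have left the compounds inactive within the tested range. Among the measured compounds shown here, the step that the limit leaves unreadable from compound 3 to compound 4 is therefore expected to be no step at all beyond the scatter. Compound 4 is estimated at 60000 nM, between 20000 nM and 200000 nM, most probably reported again as a limit in this assay.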

Compound 4, half-maximal inhibitory concentration: > 50000 nM
Compound 4: a limit, no number (the forecaster's own chance of this, stated with the estimate: 85%); the middle value does not contradict the limit.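

In this assay compound 4 gives > 50000 nM, a limit and not a number. Its steps to compound 1, compound 2 and compound 3 cannot be read, and all four compounds rest at one value: the limit of > 50000 nM in this assay, at which 4 of the 4 values shown sit. The compounds shown leave open whether any aryl group on this aromatic nitrogen would give a measurable value in this assay.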